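A few compounds are considered here, and "the series" means these few. Any claim that something is new, unique, unknown or untested is made for them only; others in the source may bear on it.

Working notes on the series. The shared core carries a substituted phenyl on an amide-type nitrogen, and that phenyl is the only part that varies. Among the measured compounds shown here, compound 1 `Cc1ccc(NC(=O)Nc2cccc(CNc3nccnc3Cl)c2)cc1C` gives 9870 nM in a functional assay on MGC-803 cells (Homo sapiens) for antiproliferative activity, read by MTT assay, with a stated time of 48 h (on this read-out higher numbers stand for weaker inhibition and lower numbers for stronger inhibition), and stands second highest of the three numbers measured so far. Compound 2 `Cc1ccc(NC(=O)Nc2cccc(CNc3nccnc3Cl)c2)c(C)c1` gives 10100 nM in this assay, and a 1.0-fold higher number from compound 1 to compound 2 (0.01 log units; within the scatter). Compound 3 `O=C(Nc1cccc(CNc2nccnc2Cl)c1)Nc1ccc(Cl)cc1Cl` gives 6430 nM in this assay; a 1.5-fold lower number from compound 1 to compound 3 (0.19 log units; within the scatter), and a 1.6-fold lower number from compound 2 to compound 3 (0.20 log units; within the scatter). Not one of these three steps leaves the scatter.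

Compound 4 `O=C(Nc1cccc(CNc2nccnc2Cl)c1)Nc1ccc(F)c(Cl)c1` is still to be measured. From compound 1 the change is 3-chloro-4-fluorophenyl in place of 3,4-dimethylphenyl on an amide-type nitrogen. For the measured compounds named here, the step that bears on it most directly is the one from compound 1 to compound 3, where a 2,4-dichlorophenyl replaced the 3,4-dimethylphenyl on the same amide-type nitrogen and the number stayed within the scatter; the step from compound 2 to compound 3 tells the same. Nothing measured here shows that exchanging the phenyl on the amide-type nitrogen moves the read-out beyond the scatter, so for compound 4 in this assay no step beyond the scatter is expected, at most a slight drift toward a lower number of the kind seen with compound 3. The expected step is a 1.3-fold lower number from compound 1 to compound 4 (0.12 log units; within the scatter). Compound 4 is therefore estimated at 7500 nM, with a range from 3500 nM to 16000 nM.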

Compound 4, half-maximal inhibitory concentration: 5020 nM
For compound 4 the middle estimate is 1.5-fold (0.17 log units) above the measured one, within the range that was stated.
By their numbers in this assay, from the lowest: compounds 4, 3, 1 and 2 (each within the scatter of the next).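

In this assay, among the compounds shown here, the 3-chloro-4-fluorophenyl on the amide-type nitrogen gives a 2.0-fold lower number from compound 1 to compound 4 (0.29 log units; within the scatter) and also a 2.0-fold lower number from compound 2 to compound 4 (0.30 log units; within the scatter) as the two steps that span the most of the series so far. For the compounds shown here, these are the first steps at this place to a phenyl carrying two different halogens, and the entering group keeps the heavy-atom count of the 3,4-dimethylphenyl, yet neither step leaves the scatter. Set against the other halogen-bearing phenyl, the change gives a 1.3-fold lower number from compound 3 to compound 4 (0.11 log units; within the scatter) and so separates the two halogen patterns no better, which leaves all four phenyls at this place without any order among them, while nothing measured here offers a reason for these numbers.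

Still open, as far as these compounds go, is whether a group of another kind on this phenyl, such as an amine or a carboxylic acid, or a longer chain in place of the phenyl, would move the read-out beyond the scatter. The compounds shown also leave open how far the read-out depends on the shared core, since that stays fixed throughout.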